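Methyl to Trifluoromethyl: Expecting the Next Step

The source may report more compounds than this note shows. Statements on the series, on what has been measured and on what is new or still open speak of the compounds shown alone.

Of the compounds shown here, three built on a shared core have been tested in a functional assay on COLO 205 cells (Homo sapiens) for inhibition, read by MTT assay, with a stated time of 24 h; a lower number here means a stronger inhibitor, a higher number a weaker inhibitor. Compound 1 `C(=N/c1ccccc1)\c1cc(-c2ccccc2)no1` carries hydrogen at the varied position and gives 89100 nM. Compound 2 `Fc1ccc(-c2cc(/C=N/c3ccccc3)on2)cc1` gives 33100 nM, and compound 3 `Cc1ccc(-c2cc(/C=N/c3ccccc3)on2)cc1` gives 28900 nM. Compound 3 holds the lowest of the three numbers, though its gap to compound 2 lies within the scatter, so those two cannot be ordered. The step of a 3.1-fold lower number from compound 1 to compound 3 (0.49 log units; beyond the scatter) is beyond the scatter, as is a 2.7-fold lower number from compound 1 to compound 2 (0.43 log units; beyond the scatter), while a 1.1-fold lower number from compound 2 to compound 3 (0.06 log units; within the scatter) is not.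

Compound 4 `FC(F)(F)c1ccc(-c2cc(/C=N/c3ccccc3)on2)cc1` differs from compound 3 in one place: trifluoromethyl in place of methyl on an aromatic carbon. The two measured steps that bear on this position each replaced hydrogen with a small group and lowered the number modestly, and the swap of fluoro for methyl changed little. Among the measured compounds shown here, no measured step exchanges methyl for trifluoromethyl, so the direction is open; the only guide is that the two substituted compounds so far sit close together in this assay. Compound 4 is therefore expected to land near compound 3, perhaps a little lower. The expected step is a 1.4-fold lower number from compound 3 to compound 4 (0.16 log units; within the scatter). The estimate for compound 4 is 20000 nM, with a range from 7000 nM to 60000 nM.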

Compound 4, half-maximal inhibitory concentration: 41300 nM
Beside the measured number, compound 4's estimate is 2.1-fold (0.31 log units) below it; measured number inside the range.
By their numbers in this assay, from the lowest: compounds 3, 2 and 4 (each within the scatter of the next); then compound 1.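

In this assay, trifluoromethyl on an aromatic carbon para to a large group cannot be told apart from either of the other two substituents, as shown by the exchange for methyl (a 1.4-fold higher number from compound 3 to compound 4 (0.16 log units; within the scatter)) and the exchange for fluoro (a 1.2-fold higher number from compound 2 to compound 4 (0.10 log units; within the scatter)), so going from the 1 heavy atom of methyl to the 4 heavy atoms of trifluoromethyl produces no readable change at this place. The gain over hydrogen also survives this larger group (a 2.2-fold lower number from compound 1 to compound 4 (0.33 log units; beyond the scatter)), which makes compound 2, compound 3 and compound 4 a single group of three, all separated from compound 1 by more than the scatter, with no compound going against this among the four shown. Nothing in hand explains why these three substituents read alike in this assay.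

The compounds shown leave open whether this level is a floor for the position or whether a different kind of group, such as an amine, a carboxylic acid or a longer chain, would move the number beyond the scatter in either direction. They also leave open whether substitution elsewhere on the shared core would do more than any change made here.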